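Methyl for Chloro: Expecting Little Movement in Splenocyte Inhibition

The compounds below may be only part of what the source reports. "The series", "measured", "known", "first", "only" and "open" are said of these compounds alone.

Of the compounds shown here, three built on one shared core have been measured so far. Compound 1 `CO/C(=C\c1ccccc1)C(=O)Nc1ccc(C)cc1` gives 16600 nM in a functional assay on cells (Splenocyte, Mus musculus, strain BALB/c) for inhibition, read by MTT assay, with a stated time of 48 h; a lower number here means a stronger inhibitor, a higher number a weaker inhibitor. Compound 2 `CO/C(=C\c1ccc(Cl)cc1)C(=O)Nc1ccc(C)cc1` gives 12700 nM in this assay; the step of a 1.3-fold lower number from compound 1 to compound 2 (0.12 log units; within the scatter) came with chloro in place of hydrogen on an aromatic carbon. Compound 3 `CO/C(=C\c1ccc(OC)cc1)C(=O)Nc1ccc(Cl)cc1` gives 14700 nM in this assay. Among the three numbers compound 3 stands second highest, nearest to compound 1 and furthest from compound 2, yet all three values sit within the usual scatter of one another, so nothing separates them.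

Compound 4 `CO/C(=C\c1ccc(OC)cc1)C(=O)Nc1ccc(C)cc1` differs from compound 3 in a single place: methyl in place of chloro on an aromatic carbon. For the measured compounds named here, the only measured step, a 1.3-fold lower number from compound 1 to compound 2 (0.12 log units; within the scatter), involved a different ring and a different pair of groups, and it stayed within the scatter, so it bears on this change only loosely. Going by the values given here, no measured pair exchanges methyl for chloro directly. Among the compounds with values here, because compound 3 gives 14700 nM and every value so far lies within the scatter of the others, the expected step for compound 4 is a 1.0-fold higher number from compound 3 to compound 4 (0.01 log units; within the scatter), that is, nothing beyond the scatter. Compound 4 is therefore estimated to give 15000 nM, with a range from 7000 nM to 32000 nM.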

Compound 4, half-maximal inhibitory concentration: 940 nM
Compound 4: middle estimate off by 16-fold (1.20 log units), on the high side; the whole stated range lies above it.
By their numbers in this assay, from the lowest: compound 4; then compounds 2, 3 and 1 (each within the scatter of the next).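

In this assay, for the compounds shown here, this place on the aromatic ring turns out to be sensitive: going from 4-chlorophenyl to 4-methylphenyl, an exchange of one heavy atom for one heavy atom, gives the first step beyond the scatter (a 16-fold lower number from compound 3 to compound 4 (1.19 log units; beyond the scatter)). The group on the other aromatic ring matters just as much, since with the 4-methylphenyl kept in place, methoxy in place of chloro (a 14-fold lower number from compound 2 to compound 4 (1.13 log units; beyond the scatter)) and methoxy in place of hydrogen (an 18-fold lower number from compound 1 to compound 4 (1.25 log units; beyond the scatter)) are both large steps, whereas chloro in place of hydrogen on that same ring stayed within the scatter (a 1.3-fold lower number from compound 1 to compound 2 (0.12 log units; within the scatter)). Neither group is enough alone among these compounds: compound 1 and compound 2 carry the methyl without the methoxy, compound 3 carries the methoxy without the methyl, and these three cannot be told apart, so the stronger inhibition appears only in compound 4, which holds both.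

Nothing in the data shown explains why the two groups stand out only in combination. As far as these compounds go, it also stays open whether an ethyl group or an amine at the methyl's place, or a hydroxyl group at the methoxy's place, would keep this stronger inhibition.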